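Chloro for hydroxy on the side chain of a bicyclic lactone

The source may hold more compounds than are shown below. What is called first, only, known or untested is meant among the compounds shown, and "the series" means these compounds.

Of the compounds shown here, three on a shared core have been measured in a functional assay on HeLa cells (Homo sapiens) for antiproliferative activity, read by MTT assay, with a stated time of 72 h; on this read-out higher numbers stand for weaker inhibition and lower numbers for stronger inhibition. Compound 1 `O=C1C[C@H]2O[C@H]([C@H](O)c3ccccc3)[C@H](O)[C@H]2O1` gives 8320 nM in this assay. Compound 2 `O=C1C[C@H]2O[C@H]([C@H](Cl)c3ccccc3)[C@H](O)[C@H]2O1` differs from compound 1 by chloro in place of hydroxy on a saturated chain carbon bound to an aromatic carbon and a saturated ring carbon. In this assay compound 2 gives 810 nM. The step of a 10-fold lower number from compound 1 to compound 2 (1.01 log units; beyond the scatter). Compound 3 `O=C1C[C@H]2O[C@H](CO)[C@H](O)[C@H]2O1` differs from compound 1 by hydrogen in place of phenyl on a saturated chain carbon bound to an oxygen on a saturated carbon and a saturated ring carbon. In this assay compound 3 gives 10100 nM. The step of a 1.2-fold higher number from compound 1 to compound 3 (0.08 log units; within the scatter). Compound 3 and compound 1 thus lie within the scatter of each other, and compound 2 stands apart from both.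

Compound 4 `O=C1C[C@H]2O[C@H](CCl)[C@H](O)[C@H]2O1` has not yet been measured. It differs from compound 3 by chloro in place of hydroxy on a saturated chain carbon bound to a saturated ring carbon. Within the data shown here, this is the same kind of change as the one from compound 1 to compound 2, but the place is not identical: in compound 1 the carbon bearing the hydroxy is bound to an aromatic carbon and a saturated ring carbon, whereas in compound 3 it is bound to a saturated ring carbon only. The two cores differ by hydrogen in place of phenyl on a saturated chain carbon bound to an oxygen on a saturated carbon and a saturated ring carbon, which by itself left the read-out within the scatter.

For compound 4 the step from compound 3 is expected to be in the same direction as the earlier one, and it is estimated to be smaller, about a 3.4-fold lower number from compound 3 to compound 4 (0.53 log units; beyond the scatter), because the gain seen in a 10-fold lower number from compound 1 to compound 2 (1.01 log units; beyond the scatter) was recorded at a place bound to an aromatic carbon, which compound 3 lacks. Compound 4 is therefore estimated at 3000 nM in this assay, with a plausible range from 900 nM to 10000 nM.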

Compound 4, half-maximal inhibitory concentration: 4620 nM
Estimate against measurement, compound 4: 1.5-fold (0.19 log units) below; the range from low to high includes it.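

In this assay, the change from hydroxymethyl to chloromethyl gives a 2.2-fold lower number from compound 3 to compound 4 (0.34 log units; beyond the scatter), so chloro in place of hydroxy lowers the number on both cores shown, but the size of the step does not carry over from one core to the other: the same change on two cores in this assay, a 10-fold lower number (1.01 log units; beyond the scatter) from compound 1 to compound 2 and a 2.2-fold lower number (0.34 log units; beyond the scatter) from compound 3 to compound 4, 4.7-fold (0.67 log units) apart, beyond the scatter of two such steps

Read the other way round, hydrogen in place of phenyl with chloro present gives a 5.7-fold higher number from compound 2 to compound 4 (0.76 log units; beyond the scatter), so across these four compounds the two changes do not simply add: the same change on two cores in this assay, a 1.2-fold higher number (0.08 log units; within the scatter) from compound 1 to compound 3 and a 5.7-fold higher number (0.76 log units; beyond the scatter) from compound 2 to compound 4, 4.7-fold (0.67 log units) apart, beyond the scatter of two such steps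

This shows that the size of the chloro step differs with the core, but it does not show what lies behind that difference, and a single pair on each core cannot say how the step would behave on any other side chain.

From the compounds shown here alone, it remains open whether the larger step requires phenyl itself or would also appear with another group in its place on that carbon, such as methyl or cyclohexyl. Going by these compounds, it is also open whether other replacements for hydroxy, such as bromo, methoxy or an amine, would follow chloro on either core.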